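Halogen on the phenyl ring in the tetrabromo series

This account rests on a few compounds, and the source may have more. Where it says the series, first, only, none or still open, it means among the compounds named here.

Compound 2 `OC(CCn1nc2c(Br)c(Br)c(Br)c(Br)c2n1)c1ccccc1` is the hydrogen-bearing member of the pair measured so far. In a functional assay on CCRF-CEM cells (Homo sapiens) for antiproliferative activity, read by MTT assay, with a stated time of 48 h, tested at 12.5 uM (on this read-out lower numbers stand for a stronger effect and higher numbers for a weaker effect at the one concentration tested), compound 2 gives 89%, the lowest of the two numbers in hand. For the measured compounds named here, its nearest neighbour is compound 1 `OC(CCn1nc2c(Br)c(Br)c(Br)c(Br)c2n1)c1ccc(F)cc1`, which in this assay gives 101%; the step of a number 12 percentage points lower from compound 1 to compound 2 (beyond the scatter) is the only single-point change measured, and it bears directly on the question, since both changes sit on an aromatic carbon para to a large group.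

Compound 3 `OC(CCn1nc2c(Br)c(Br)c(Br)c(Br)c2n1)c1ccc(Br)cc1` differs from compound 2 by bromo in place of hydrogen on an aromatic carbon. Going by the values given here, the one measured step shows that taking a halogen off this ring lowered the number beyond the scatter, so putting a halogen back is expected to move the number upward in this assay; bromo is not fluoro, and only one pair informs the direction, so the expected size is modest and the range wide. The estimate for compound 3 in this assay is 96%, within 82% to 110%, an expected step of a number 7 percentage points higher from compound 2 to compound 3 (within the scatter).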

Compound 3, a percentage reported as activity, at one concentration (the size of the read-out at that concentration, not a potency): 89%
Compound 3: middle estimate off by 7 percentage points, on the high side; the range from low to high includes it.
By their numbers in this assay, from the lowest: compounds 2 and 3 (each within the scatter of the next); then compound 1.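

In this assay, for the compounds shown here, bromo in place of hydrogen on the aromatic carbon para to a large group gives no change at the digits printed from compound 2 to compound 3 (within the scatter), so the presence of a halogen at this position does not by itself separate compound 3 from compound 2, which the single fluoro-to-hydrogen step could not show. Exchanging one halogen for the other gives a number 12 percentage points lower from compound 1 to compound 3 (beyond the scatter), so among these three compounds the higher number belongs to the fluoro member alone, and the earlier reading of a general halogen effect does not hold, with compound 3 as the compound against it. Nothing available explains why fluoro and bromo part in this way at this position.

Three compounds cannot show whether fluoro is the exception here or whether other groups at this position, such as chloro, methoxy, an amine or a carboxylic acid, would fall with the hydrogen and bromo members or with the fluoro member. From the compounds shown here alone, the response to changes elsewhere, such as a longer chain in place of the present one or an amine in place of the hydroxyl group, also remains open.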